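The compounds below may be only part of what the source reports. "The series", "measured", "known", "first", "only" and "open" are said of these compounds alone.

Compound 1 `COc1ccc(/C=C/C(=O)c2sc(Nc3ccc(Cl)c(Cl)c3)nc2C)cc1`: in a functional assay on PC-3 cells (Homo sapiens) for cytotoxicity, read by MTT assay (a lower number here means a stronger inhibitor, a higher number a weaker inhibitor), compound 1 gives > 25000 nM, a limit of the assay.
Compound 2 `Cc1ccccc1Nc1nc(C)c(C(=O)/C=C/c2ccccc2)s1`: in this assay compound 2 gives > 25000 nM, a limit of the assay.
Compound 3 `COc1ccc(/C=C/C(=O)c2sc(Nc3ccc(Cl)cc3)nc2C)cc1`: in this assay compound 3 gives > 25000 nM, a limit of the assay.

Compound 3 stands at the limit, and so do all values shown so far (the limit of > 25000 nM in this assay, at which 3 of the 3 values shown sit). Among the measured compounds shown here, the single measured step, a step that the two limits leave unreadable from compound 1 to compound 3, runs between two limits and is unreadable. Compound 4 `Cc1nc(Nc2ccc(Cl)cc2)sc1C(=O)/C=C/c1ccccc1` differs from compound 3 by hydrogen in place of methoxy on an aromatic carbon. For the measured compounds named here, no measured step covers this change. Compound 2, which also carries the phenyl on the enone, sits at the limit in this assay. No step beyond the scatter is therefore expected. Compound 4 is expected at 40000 nM (range 25000 nM to 100000 nM), most likely reported as a limit only. The expected step is a step that the limit leaves unreadable from compound 3 to compound 4.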

Compound 4, half-maximal inhibitory concentration: 24600 nM
Compound 4: middle estimate off by 1.6-fold (0.21 log units), on the high side; the whole stated range lies above it.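

In this assay, among the compounds shown here, exchanging 4-methoxyphenyl for phenyl gives an at least 1.0-fold lower number from compound 3 to compound 4 (0.00 log units; that floor lies within the scatter), and this is the first reading that is a number rather than a limit. Exchanging 2-methylphenyl for 4-chlorophenyl on the nitrogen gives an at least 1.0-fold lower number from compound 2 to compound 4 (0.00 log units; that floor lies within the scatter). Both floors lie within the scatter, so neither change is shown to improve the series, which stays at the edge of what the assay reads: the limit of > 25000 nM in this assay, at which 3 of the 4 values shown sit.

As far as these compounds go, it remains open whether an amine or a carboxylic acid on that same aromatic carbon would give a value clear of the limit in this assay.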